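This account rests on a few compounds, and the source may have more. Where it says the series, first, only, none or still open, it means among the compounds named here.

Measured compounds in a functional assay on MCF7 cells (Homo sapiens) for antiproliferative activity, read by MTT assay, with a stated time of 48 h; on this read-out lower numbers stand for stronger inhibition and higher numbers for weaker inhibition:
- compound 1 `O=C(/C=C/c1cccc(NC(=O)c2ccccc2Cl)c1)c1nc2ccccc2[nH]1`: 4570 nM
- compound 2 `O=C(/C=C/c1cccc(NC(=O)c2ccccc2Br)c1)c1nc2ccccc2[nH]1`: 4520 nM
- compound 3 `O=C(Nc1cccc(/C=C/C(=O)c2nc3ccccc3[nH]2)c1)c1ccc(Br)cc1`: 7000 nM

Compound 3 gives the highest of the three numbers, but its distance to compound 1 and to compound 2 is within the scatter: a 1.5-fold higher number from compound 1 to compound 3 (0.19 log units; within the scatter) and a 1.5-fold higher number from compound 2 to compound 3 (0.19 log units; within the scatter) are both small. The halogen swap a 1.0-fold lower number from compound 1 to compound 2 (0.00 log units; within the scatter) is likewise flat.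

Compound 4 `O=C(/C=C/c1cccc(NS(=O)(=O)c2ccccc2Cl)c1)c1nc2ccccc2[nH]1` differs from compound 3 by (2-chlorophenyl)sulfonyl in place of (4-bromophenyl)carbonyl on a nitrogen on an aromatic ring. Going by the values given here, two measured steps bear on part of this change: moving the bromine from the 4-position to the 2-position of the phenyl on the carbonyl, read backwards from compound 3 to compound 2, gave only a small move within the scatter, as did the corresponding move to compound 1. Among the compounds with values here, no measured pair covers the exchange of carbonyl for sulfonyl, so that part of the change is unanchored.

Compound 4 is therefore expected to sit near compound 3 in this assay, with the step of a 1.6-fold lower number from compound 3 to compound 4 (0.19 log units; within the scatter) estimated to lie within the scatter. The estimate for compound 4 is 4500 nM, with a range from 1500 nM to 14000 nM.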

Compound 4, half-maximal inhibitory concentration: 4280 nM
Compound 4: middle estimate off by 1.1-fold (0.02 log units), on the high side, and the stated range covers the measured number.
By their numbers in this assay, from the lowest: compounds 4, 2, 1 and 3 (each within the scatter of the next).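

In this assay, the exchange of carbonyl for sulfonyl on the nitrogen on an aromatic ring can now be read on its own, with the 2-chlorophenyl kept in place (a 1.1-fold lower number from compound 1 to compound 4 (0.03 log units; within the scatter)), and it stays flat. The steps that also change the halogen (a 1.1-fold lower number from compound 2 to compound 4 (0.02 log units; within the scatter)) or both the halogen and its ring position (a 1.6-fold lower number from compound 3 to compound 4 (0.21 log units; within the scatter)) likewise stay within the scatter, so this place has carried both carbonyl and sulfonyl without a move beyond it. No measurement shown here offers an explanation for this result.

As far as these compounds go, whether this flatness extends to other groups on the sulfonyl, such as methyl or 4-bromophenyl, remains open. Also open, from the compounds shown here alone, is whether an amine or a carboxylic acid on the phenyl in place of the halogen would move the number beyond the scatter.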